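Third methoxy on the aryl ketone of compound 2

The source may hold more compounds than are shown below. What is called first, only, known or untested is meant among the compounds shown, and "the series" means these compounds.

Three compounds of the shared core have been run in a functional assay on MDA-MB-435 cells (Homo sapiens) for cytotoxicity, read by sulforhodamine B assay, with a stated time of 48 h, tested at 100 uM; on this read-out higher numbers stand for a weaker effect at the one concentration tested and lower numbers for a stronger effect. Compound 1 `COc1cc(-c2cc(/C=C/C(=O)c3ccc(N)cc3)[nH]n2)cc(OC)c1OC` gives -85%, compound 2 `COc1ccc(C(=O)/C=C/c2cc(-c3cc(OC)c(OC)c(OC)c3)n[nH]2)cc1OC` gives -73%, and compound 3 `COc1cc(-c2cc(/C=C/C(=O)c3ccc(F)c(F)c3)[nH]n2)cc(OC)c1OC` gives -34%. Compound 2 stands second highest of the three: the step of a number 12 percentage points higher from compound 1 to compound 2 (beyond the scatter) is modest, and the step of a number 39 percentage points higher from compound 2 to compound 3 (beyond the scatter) is large. Compound 4 `COc1cc(C(=O)/C=C/c2cc(-c3cc(OC)c(OC)c(OC)c3)n[nH]2)cc(OC)c1OC` differs from compound 2 by methoxy in place of hydrogen on an aromatic carbon on the 3,4-dimethoxyphenyl group of compound 2. Going by the values given here, no measured step exchanges hydrogen for methoxy; the steps that alter the group on the carbonyl carbon are a number 12 percentage points higher from compound 1 to compound 2 (beyond the scatter) and a number 51 percentage points higher from compound 1 to compound 3 (beyond the scatter), and only the first is modest. A step in this assay of about a number 5 percentage points higher from compound 2 to compound 4 (within the scatter) is therefore expected, within or barely beyond the scatter. Compound 4 is estimated at -68%, in the range -88% to -45%.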

Compound 4, a percentage reported as activity, at one concentration (the size of the read-out at that concentration, not a potency): -83%
For compound 4 the middle estimate is 15 percentage points above the measured one; the measured number falls inside the stated range.
By their numbers in this assay, from the lowest: compounds 1, 4 and 2 (each within the scatter of the next, the first and the last beyond it); then compound 3.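

In this assay, methoxy in place of hydrogen on this aromatic carbon gives a number 10 percentage points lower from compound 2 to compound 4 (within the scatter), so this position accepts the added group without a change that can be told from the scatter. The earlier steps shown here exchanged the whole aryl group on the carbonyl carbon; this one alters a single carbon of that ring and leaves the read-out in place. No measurement on hand explains this result.

From the compounds shown here alone, whether an ethoxy group, a hydroxyl group or an amine on the same carbon would behave like methoxy remains open. So does whether the effect at other concentrations would match what this single-concentration read-out shows.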